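The source may report more compounds than this note shows. Statements on the series, on what has been measured and on what is new or still open speak of the compounds shown alone.

- Compound 1 `N#Cc1c(-c2nnc(O)c3nn(-c4ccccc4)cc23)nn(-c2ccccc2)c1-c1ccccc1`: 2760 nM
- Compound 2 `N#Cc1c(-c2nnc(O)c3nn(-c4ccc(Cl)cc4)cc23)nn(-c2ccccc2)c1-c1ccccc1`: > 100000 nM (a limit, not a number)

Both compounds were tested in a functional assay on NCI/ADR-RES cells (Homo sapiens) for inhibition, read by sulforhodamine B assay, with a stated time of 48 h; on this read-out higher numbers stand for weaker inhibition of growth and lower numbers for stronger inhibition of growth. From the compounds shown here alone, compound 2 stands at > 100000 nM, which is a limit of the assay, so its true position is unknown.

Compound 3 `N#Cc1c(-c2nnc(-c3ccccc3)c3nn(-c4ccc(Cl)cc4)cc23)nn(-c2ccccc2)c1-c1ccccc1` keeps the chloro group of compound 2 and carries phenyl in place of hydroxy on an aromatic carbon.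

For the measured compounds named here, only one measured step is available, an at least 36-fold higher number from compound 1 to compound 2 (1.55 log units; beyond the scatter), and it is large. Going by the values given here, that step is chloro in place of hydrogen, so it does not touch the hydroxy, and no measured step covers the present exchange. Among the compounds with values here, it shows only that small changes can matter a great deal. Compound 1, at 2760 nM, shows that the shared core can give a measurable number. A moderate move towards stronger inhibition of growth is therefore expected, though compound 3 may well remain at the limit. The expected value for compound 3 is 30000 nM, with an estimated range from 5000 nM to 100000 nM. The estimate corresponds to an expected at least 3.3-fold lower number from compound 2 to compound 3 (0.52 log units; beyond the scatter).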

Compound 3, concentration for 50% growth inhibition: 2280 nM
Beside the measured number, compound 3's estimate is 13-fold (1.12 log units) above it, outside the stated range (below it).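

On an aromatic carbon next to the ring nitrogen, phenyl in place of hydroxy gives an at least 43-fold lower number from compound 2 to compound 3 (1.64 log units; beyond the scatter) in this assay, so this position, which the earlier step did not touch, responds strongly to the exchange. The result also shows that the chloro group does not by itself rule out a measured number in this series: compound 3 keeps that group and still gives a measured number, 2280 nM. For compound 2, > 100000 nM is a limit, not a number, so the step gives only a minimum size: the limit of > 100000 nM in this assay, at which 1 of the 3 values shown sits.

The compounds shown cannot tell whether the change in growth inhibition comes from the arrival of phenyl or from the loss of hydroxy, and an amine, a methoxy group or a methyl group on the same carbon would help to separate the two. From the compounds shown here alone, it also stays open how the same exchange would read on compound 1, which carries hydrogen in place of the chloro group, and so whether the size of this step depends on that group.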